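Swapping selenium for sulfur on a quinoline-type core

The source may report more compounds than this note shows. Statements on the series, on what has been measured and on what is new or still open speak of the compounds shown alone.

Measured compounds:
- compound 1, `OCC#CCSc1cnc2ccccc2c1SCC#CCO`: 2.6 ug/mL
- compound 2, `C#CCSc1cnc2ccccc2c1[Se]CC#CCO`: 3.2 ug/mL

Both compounds were tested in a functional assay on CCRF-CEM cells (Homo sapiens) for cytotoxicity, read by sulforhodamine B assay, with a stated time of 72 h; a lower number here means a stronger inhibitor, a higher number a weaker inhibitor. Of the two numbers, that of compound 2 is the higher, but compound 1 sits within the usual scatter of it, so the two cannot be told apart on these data alone.

Compound 3, `C#CCSc1cnc2ccccc2c1SCC#CCO`, has not yet been measured. It differs from compound 2 in one place: a group of 6 heavy atoms (4 carbon, 1 oxygen, 1 sulfur; no ring) in place of a group of 6 heavy atoms (4 carbon, 1 oxygen, 1 selenium; no ring), on an aromatic carbon. Compound 1, which carries sulfur at both positions, gives a number close to compound 2, so the same exchange is not expected to move the result much. The step of a 1.1-fold lower number from compound 2 to compound 3 (0.06 log units; within the scatter) is expected to be small and to stay within the scatter, in either direction. Compound 3 is therefore estimated at 2.8 ug/mL, with a likely range from 1.4 ug/mL to 5.6 ug/mL.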

Compound 3, concentration for 50% inhibition: 3.2 ug/mL
The estimate for compound 3 lay 1.1-fold (0.06 log units) below the measured number; the measured number falls inside the stated range.
By their numbers in this assay, from the lowest: compounds 1, 2 and 3 (each within the scatter of the next).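

Going by these compounds alone, compound 1 and compound 2 differ in two places, so only this pair isolates the exchange of selenium for sulfur on the aromatic carbon opposite the ring nitrogen: in this assay, the exchange gives no change at the digits printed from compound 2 to compound 3 (within the scatter). The other pair isolates the end of one chain, and hydrogen in place of hydroxymethyl on a triple-bonded carbon gives a 1.2-fold higher number from compound 1 to compound 3 (0.09 log units; within the scatter), so neither single change separates its two compounds in this assay. Nothing available explains why these numbers stay so close.

The compounds shown compare only sulfur with selenium at the first place and only hydrogen with hydroxymethyl at the second. On these data alone, whether an amine at the end of the chain, a carboxylic acid or a longer chain would shift the number remains open.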